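From Butyl to Propyl on Compound 1

The compounds below may be only part of what the source reports. "The series", "measured", "known", "first", "only" and "open" are said of these compounds alone.

In a functional assay on SW1573 cells (Homo sapiens) for antiproliferative activity, read by sulforhodamine B assay, with a stated time of 48 h (on this read-out lower numbers stand for stronger inhibition of growth and higher numbers for weaker inhibition of growth), compound 1 (`CCCCC(C#CC(=O)OC)O/C=C/C(=O)OC`) gives 240 nM, the lowest of the two actual numbers. Compound 2 (`CCOC(=O)C#CC(O/C=C/C(=O)OCC)C(C)C`) gives 2800 nM, a gap beyond the usual scatter. Compound 3 (`CC1CCC(C(C)C)C(OC(=O)C#CC(O/C=C/C(=O)OC2CC(C)CCC2C(C)C)C(C)C)C1`) shows > 100000 nM, which is a limit and not a number. Compound 4 (`CCCC(C#CC(=O)OC)O/C=C/C(=O)OC`) is still unmeasured. Its change from compound 1 is hydrogen in place of methyl on a saturated chain carbon, four bonds along the chain from an oxygen on an unsaturated carbon and a triple-bonded carbon, which turns butyl into propyl. Among the measured compounds shown here, no measured pair isolates this change, so the guide is thin: compound 1, at 240 nM, already holds the lowest number, so a rise seems likelier than a fall. In this assay, the expected step of a 1.9-fold higher number from compound 1 to compound 4 (0.27 log units; within the scatter) is a modest rise, meaning somewhat weaker growth inhibition. Compound 4 is estimated at 450 nM, with an expected range of 120 nM to 1800 nM.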

Compound 4, concentration for 50% growth inhibition: 320 nM
For compound 4 the middle estimate is 1.4-fold (0.15 log units) above the measured one; the range from low to high includes it.
By their numbers in this assay, from the lowest: compounds 1 and 4 (each within the scatter of the next); then compound 2. At a limit, above all of these: compound 3.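

Going from butyl to propyl gives a 1.3-fold higher number from compound 1 to compound 4 (0.12 log units; within the scatter) in this assay and is the first single change that can be read at this chain position. The two compounds therefore cannot be told apart in this assay, so a chain one carbon shorter keeps growth inhibition within the usual scatter of compound 1.

On these data alone, whether a longer chain such as hexyl, a shorter one such as ethyl, or a phenyl ring at this place would do the same remains open. No measurement shown bears on why this step is so small.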